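This account rests on a few compounds, and the source may have more. Where it says the series, first, only, none or still open, it means among the compounds named here.

Measured in a functional assay on NCI-H460 cells (Homo sapiens) for cytotoxicity, read by MTT assay, with a stated time of 48 h; on this read-out higher numbers stand for lower toxicity in this test and lower numbers for higher toxicity in this test:

- Compound 1 `O=C1Nc2ccccc2/C1=N/NC(=S)N1CCN(C(=O)NO)CC1`: > 100000 nM
- Compound 2 `O=C(NO)N1CCN(C(=S)N/N=C/c2ccccc2Cl)CC1`: > 100000 nM

Compound 2 stands at > 100000 nM, which is a limit of the assay and not a number. Compound 1 also gives only a limit, and the two share one position: the limit of > 100000 nM in this assay, at which 2 of the 2 values shown sit. Neither compound therefore offers an exact value to compare.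

Compound 3 `O=C(NO)N1CCN(C(=S)N/N=C/c2ccc(Cl)cc2)CC1` has the same atoms as compound 2, joined differently. It carries 4-chlorophenyl in place of 2-chlorophenyl on a carbon with a double bond to nitrogen. Going by the values given here, no measured pair shows what such a change does in this assay. The expected step of a number no higher from compound 2 to compound 3 (the limit leaves the size open) is therefore none beyond the usual scatter, and another limit is the likeliest report. For compound 3 the estimated value is 100000 nM, with an expected range from 50000 nM to 200000 nM.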

Compound 3, concentration lethal to 50% of the cells: > 100000 nM
Compound 3: no number, only a limit; the forecaster's own chance of this, stated with the estimate: 80%; the middle value sits exactly at the limit.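

Compound 2 and compound 3 both give only a limit of the assay, so no step can be read between them: the limit of > 100000 nM in this assay, at which 3 of the 3 values shown sit. On these data alone, what 4-chlorophenyl in place of 2-chlorophenyl changes stays open, as does any ranking of compound 1, compound 2 and compound 3, none of which has an exact value.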